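Fluoro to chloro on the cyclopropyl quinolone series

The source may hold more compounds than are shown below. What is called first, only, known or untested is meant among the compounds shown, and "the series" means these compounds.

Cytotoxicity is followed in a functional assay on V79 cells (Cricetulus griseus) for cytotoxicity, read by colony formation; on this read-out lower numbers stand for stronger inhibition and higher numbers for weaker inhibition. Compound 1 `CNCC1(C)CCN(c2c(F)cc3c(=O)c(C(=O)O)cn(C4CC4)c3c2F)C1` gives 8 ug/mL, compound 2 `CNCC1(C)CCN(c2c(F)cc3c(=O)c(C(=O)O)cn(C4CC4)c3c2Cl)C1` gives 23 ug/mL, and compound 3 `O=C(O)c1cn(C2CC2)c2c(F)c(N3CCNCC3)c(F)cc2c1=O` gives 47 ug/mL in this assay.

Two steps connect them. The change chloro in place of fluoro on an aromatic carbon brings a 2.9-fold higher number from compound 1 to compound 2 (0.46 log units; beyond the scatter). The change piperazin-1-yl in place of 3-methyl-3-((methylamino)methyl)pyrrolidin-1-yl on an aromatic carbon brings a 5.9-fold higher number from compound 1 to compound 3 (0.77 log units; beyond the scatter). Compound 3 thus has the highest number of the three, with compound 2 nearest and compound 1 furthest from it.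

Compound 4 `O=C(O)c1cn(C2CC2)c2c(Cl)c(N3CCNCC3)c(F)cc2c1=O` has not yet been measured. It differs from compound 3 by chloro in place of fluoro on an aromatic carbon. Within the data shown here, this is the same kind of change as the one from compound 1 to compound 2, not the same change: in compound 1 the carbon is ortho to a 3-methyl-3-((methylamino)methyl)pyrrolidin-1-yl group, in compound 3 it is ortho to a piperazin-1-yl group. The two cores differ by piperazin-1-yl in place of 3-methyl-3-((methylamino)methyl)pyrrolidin-1-yl on an aromatic carbon.

For compound 4 the step in this assay is expected to resemble the earlier one, estimated as a 2.3-fold higher number from compound 3 to compound 4 (0.37 log units; beyond the scatter), resting on the step from compound 1 to compound 2, which was a 2.9-fold higher number from compound 1 to compound 2 (0.46 log units; beyond the scatter); a single earlier occurrence gives limited confidence, and the change sits beside a different amine group. For compound 4 the expected value in this assay is 110 ug/mL, with an estimated range from 50 ug/mL to 250 ug/mL.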

Compound 4, half-maximal inhibitory concentration: 43 ug/mL
Beside the measured number, compound 4's estimate is 2.6-fold (0.41 log units) above it; the measured number lies below the stated range.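

In this assay, chloro in place of fluoro does not carry over unchanged from the core of compound 1 to the core with the piperazin-1-yl group, where the step is a 1.1-fold lower number from compound 3 to compound 4 (0.04 log units; within the scatter), and the two occurrences stand clearly apart: the same change on two cores in this assay, a 2.9-fold higher number (0.46 log units; beyond the scatter) from compound 1 to compound 2 and a 1.1-fold lower number (0.04 log units; within the scatter) from compound 3 to compound 4, 3.1-fold (0.50 log units) apart, beyond the scatter of two such steps

Read along the amine, the same four compounds give a 1.9-fold higher number from compound 2 to compound 4 (0.27 log units; within the scatter), so the exchange of amines also depends on which halogen is present: the same change on two cores in this assay, a 5.9-fold higher number (0.77 log units; beyond the scatter) from compound 1 to compound 3 and a 1.9-fold higher number (0.27 log units; within the scatter) from compound 2 to compound 4, 3.1-fold (0.50 log units) apart, beyond the scatter of two such steps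

For compounds 1 to 4 the two changes therefore do not add up, and a step seen on one core is a weak guide to the same step on the other, but with a single pair per core this does not show why the steps part or whether either step would hold on a further core.

Open, as far as these compounds go, is whether a bromo or methoxy group on the same aromatic carbon would follow the step seen with the 3-methyl-3-((methylamino)methyl)pyrrolidin-1-yl group or the one seen with the piperazin-1-yl group. Also open, from the compounds shown here alone, is how the chloro and fluoro pair would behave with a 4-methylpiperazin-1-yl or a 3-aminopyrrolidin-1-yl group in place of these amines.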